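The source may hold more compounds than are shown below. What is called first, only, known or untested is meant among the compounds shown, and "the series" means these compounds.

Measured in an in vitro ADME assay on microsomes from liver (Mus musculus) for pharmacokinetics, read by LC-MS; a lower number here means slower removal, a higher number faster removal of the compound:

- compound 1 `Cc1ccc2nc(C)n(-c3ccc(C(=O)NC4CC4)s3)c2c1`: > 72 mL/min/kg
- compound 2 `COc1cccc2c1nc(C)n2-c1ccc(C(=O)NC2CC2)s1`: > 72 mL/min/kg

Compound 1 stands at a limit of the assay, not at a number: > 72 mL/min/kg. Compound 2 also gives only a limit, > 72 mL/min/kg. The picture so far is therefore (the limit of > 72 mL/min/kg in this assay, at which 2 of the 2 values shown sit).

Compound 3 `Cc1nc2ccc(F)cc2n1-c1ccc(C(=O)NC2CC2)s1` changes one group of compound 1: fluoro in place of methyl on an aromatic carbon. Going by the values given here, no measured step shows what such a swap does in this assay. A small fall in clearance is expected, or none beyond the scatter, and the expected step is an at least 1.2-fold lower number from compound 1 to compound 3 (0.09 log units; that floor lies within the scatter). The estimate for compound 3 is 58 mL/min/kg, with an expected range of 28 mL/min/kg to 72 mL/min/kg.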

Compound 3, clearance: > 72 mL/min/kg
Compound 3 was reported as a limit; the forecaster's own chance of this, stated with the estimate: 50%; at least 1.2-fold (0.09 log units) between middle value and limit.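

Going by these compounds alone, compound 1 and compound 3 both give only a limit in this assay, so no step between them can be read. The compounds shown leave open how fast each is really removed, and whether fluoro in place of methyl changes that.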